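A few compounds are considered here, and "the series" means these few. Any claim that something is new, unique, unknown or untested is made for them only; others in the source may bear on it.

Measured compounds:
compound 1 `O=C([C@H]1CC2CCC1C2)N1CC(c2nc(-c3ccccc3)no2)C1`, 120 nM
compound 2 `O=C(C1CCC2(CCC2)CC1)N1CC(c2nc(-c3cccc(Cl)c3)no2)C1`, 1100 nM
compound 3 `Cc1ccc(S(=O)(=O)N2CC(c3nc(-c4cccc(Cl)c4)no3)C2)cc1`, > 10000 nM

In an assay on HEK293 cells for positive allosteric modulation of metabotropic glutamate receptor 5 (Homo sapiens), read by FLIPR (a higher number here means that more compound is needed for the effect, a lower number that less compound is needed), compound 2 gives 1100 nM, the highest of the two numbers reported. Its nearest neighbour is compound 1, which in this assay gives 120 nM, a gap that lies beyond the usual scatter. Compound 3 reaches only the limit of this assay, > 10000 nM; it is a limit and not a number (the limit of > 10000 nM in this assay, at which 1 of the 3 values shown sits).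

Compound 4 `O=C([C@@H]1CC2CCC1C2)N1CC(c2nc(-c3cccc(Cl)c3)no2)C1` has not yet been measured. Relative to compound 2 it differs on a carbonyl carbon: a group of 7 heavy atoms (7 carbon; 2 five-membered non-aromatic rings of carbon only) in place of a group of 9 heavy atoms (9 carbon; one four-membered non-aromatic ring of carbon only, one six-membered non-aromatic ring of carbon only), on a carbonyl carbon. Within the data shown here, no measured pair separated by exactly this change exists, so the step can only be anticipated. Since compound 1, whose acyl part is likewise built from 2 five-membered non-aromatic rings of carbon only, gives 120 nM, compound 4 is expected to land at a lower number than compound 2, by more than the scatter. The estimated step from compound 2 to compound 4 in this assay is a 5.0-fold lower number from compound 2 to compound 4 (0.70 log units; beyond the scatter). For compound 4 the expected value in this assay is 220 nM, with a likely range from 70 nM to 700 nM.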

Compound 4, half-maximal effective concentration: 98 nM
Beside the measured number, compound 4's estimate is 2.2-fold (0.35 log units) above it; low and high end bracket the measured number.
By their numbers in this assay, from the lowest: compounds 4 and 1 (each within the scatter of the next); then compound 2. At a limit, above all of these: compound 3.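

In this assay, among these compounds, the replacement at the carbonyl carbon gives an 11-fold lower number from compound 2 to compound 4 (1.05 log units; beyond the scatter) and is the only change here that can be read in one place. It shows that this position responds to the choice of carbon-only acyl group: the group with 2 five-membered non-aromatic rings gives a clearly lower number than the group with one four-membered and one six-membered non-aromatic ring, while the rest of the structure stays the same. No measured property among the compounds shown accounts for this step.

The compounds shown leave open how an open-chain acyl group, such as tert-butyl or a longer chain, or an acyl group carrying an amine, would behave on this carbonyl carbon. They also leave open whether the mirror-image form of the group in compound 4 would give a similar number.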